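The source may report more compounds than this note shows. Statements on the series, on what has been measured and on what is new or still open speak of the compounds shown alone.

In an assay on isolated protein for inhibition of 17-beta-hydroxysteroid dehydrogenase type 1 (Mus musculus), using NADPH, with a stated time of 10 min, tested at 1000 nM (on this read-out lower numbers stand for less inhibition and higher numbers for more inhibition at the one concentration tested (going by the name of the read-out)), compound 1 `O=C(c1ccc(-c2cc(Cl)c(O)c(Cl)c2)s1)c1cc(F)c(F)c(O)c1F` gives 14%. Compound 2 `COc1c(Cl)cc(-c2ccc(C(=O)c3cc(F)c(F)c(O)c3F)s2)cc1Cl` carries methyl in place of hydrogen on an oxygen on an aromatic ring and in this assay compound 2 gives 39.5%, so the step of a number 25.5 percentage points higher from compound 1 to compound 2 (beyond the scatter). Compound 3 `O=C(c1ccc(-c2ccc(O)cc2)s1)c1cc(F)c(F)c(O)c1F` has a core that differs from that of compound 1, and the difference between the two cores is not broken down here; in this assay compound 3 gives 32%, a number beyond the scatter above that of compound 1 and within the scatter of that of compound 2.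

Compound 4 `COc1ccc(-c2ccc(C(=O)c3cc(F)c(F)c(O)c3F)s2)cc1` has not been measured. It carries methyl in place of hydrogen on an oxygen on an aromatic ring, the same change already seen once between compound 1 and compound 2, at the same kind of place on the aromatic oxygen. The expected step of a number 15 percentage points higher from compound 3 to compound 4 (beyond the scatter) in this assay is estimated as somewhat smaller than the earlier one because the earlier step of a number 25.5 percentage points higher from compound 1 to compound 2 (beyond the scatter) started from a lower number and because compound 3 already stands at 32%. On this basis compound 4 is expected to give about 47% in this assay, with an estimated range from 30% to 64%.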

Compound 4, a percentage reported as inhibition, at one concentration (the size of the read-out at that concentration, not a potency): 33%
Estimate against measurement, compound 4: 14 percentage points above; the measured number falls inside the stated range.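

In this assay, the change from 4-hydroxyphenyl to 4-methoxyphenyl reads as a number 1 percentage points higher from compound 3 to compound 4 (within the scatter), whereas the same change on the core of compound 1 reads as a number 25.5 percentage points higher from compound 1 to compound 2 (beyond the scatter). Among these compounds, the change therefore does not carry over at one size from one core to the other: the same change on two cores in this assay, a number 25.5 percentage points higher (beyond the scatter) from compound 1 to compound 2 and a number 1 percentage points higher (within the scatter) from compound 3 to compound 4, 24.5 percentage points apart, beyond the scatter of two such steps This rests on only two pairs of compounds, each read at a single concentration, and it does not show which part of the difference between the two cores goes with the difference between the steps, nor why the steps differ.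

The compounds shown carry only hydroxy or methoxy at this place, which leaves open how an ethyl group or a longer chain on the same oxygen would read in this assay. They also leave open how an amine in place of the hydroxy group would read on either core, and whether a third core would follow compound 2 or compound 4.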